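Bromo for methoxy on a thiazole-carboxamide indole scaffold

The source may hold more compounds than are shown below. What is called first, only, known or untested is meant among the compounds shown, and "the series" means these compounds.

The measured compounds:
Compound 1, `O=C(NCc1ccccc1)c1csc(-c2c[nH]c3ccccc23)n1`. In a functional assay on LNCaP C4-2 cells (Homo sapiens) for cytotoxicity, read by MTT assay, with a stated time of 48 h, in the presence of a further agent that is not named here (on this read-out higher numbers stand for weaker inhibition and lower numbers for stronger inhibition), compound 1 gives > 100000 nM, which is a limit of the assay rather than a number.
Compound 2, `COc1ccc2[nH]cc(-c3nc(C(=O)Nc4cc(OC)c(OC)c(OC)c4)cs3)c2c1`. In this assay compound 2 gives > 100000 nM, again a limit of the assay and not a number.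

Among the measured compounds shown here, compound 2 therefore stands at the edge of what this assay can report: both values shown sit at the limit of > 100000 nM in this assay, at which 2 of the 2 values shown sit, so no ordering between compound 1 and compound 2 can be drawn, and no step between measured compounds is available.

Compound 3, `COc1cc(NC(=O)c2csc(-c3c[nH]c4ccc(Br)cc34)n2)cc(OC)c1OC`, is the next compound to be measured. It differs from compound 2 by bromo in place of methoxy on an aromatic carbon. For the measured compounds named here, with no measured step to build on and both known values resting at the limit, the expected step in this assay from compound 2 to compound 3 is none beyond the usual scatter, and most likely compound 3 will also return only a limit. The estimate for compound 3 in this assay is 100000 nM, within a range from 20000 nM to 300000 nM, corresponding to an expected step of a number no higher from compound 2 to compound 3 (the limit leaves the size open).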

Compound 3, half-maximal inhibitory concentration: > 100000 nM
Compound 3: no number, only a limit; the forecaster's own chance of this, stated with the estimate: 80%; the middle value lies on the limit itself.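

In this assay compound 3 gives > 100000 nM as a limit of the assay and not a number, so no step from compound 2 to compound 3 can be read: the limit of > 100000 nM in this assay, at which 3 of the 3 values shown sit.

The compounds shown leave open whether bromo in place of methoxy on an aromatic carbon makes any difference in this assay at all.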